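The source may hold more compounds than are shown below. What is called first, only, known or untested is meant among the compounds shown, and "the series" means these compounds.

Measured compounds in the series:
compound 1, `O=C1Nc2ccc(C(c3ccccc3)c3ccccc3)cc2/C1=C/c1cccc(OCc2cn(Cc3ccccc3)nn2)c1`, with 17200 nM
compound 2, `Cc1ccc(C(C#Cc2ccccc2)c2ccc3c(c2)/C(=C/c2cccc(OCc4cn(Cc5ccccc5)nn4)c2)C(=O)N3)cc1`, with > 50000 nM

Both have been run in a functional assay on PC-3 cells (Homo sapiens) for inhibition, read by MTT assay, with a stated time of 48 h; a higher number here means a weaker inhibitor, a lower number a stronger inhibitor. Compound 1 gives 17200 nM. Compound 2 returns only the assay limit, > 50000 nM, so where compound 2 stands on the numbers is known only as a limit; this is the limit of > 50000 nM in this assay, at which 1 of the 2 values shown sits. Compound 1 sits within the measured range and compound 2 does not, and nothing more can be sized between them.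

Compound 3, `Cc1ccc(C(C#Cc2ccccc2)c2ccc3c(c2)/C(=C\c2cccc(OCc4cn(Cc5ccccc5)nn4)c2)C(=O)N3)cc1`, is the next entry. Relative to compound 2 it changes by the two compounds have the same atoms and bonds; at least one stereo element is drawn with a configuration in one of them and without one in the other: 1 of 2 stereo elements differ; a double bond is drawn Z in compound 2 and E in compound 3: the two compounds have the same atoms and bonds; a double bond is drawn Z in compound 2 and E in compound 3. For the measured compounds named here, no measured pair in the set differs only in this way, so the size of the step in this assay is open; it may fall in either direction or stay within the scatter. Compound 3 is expected at 40000 nM, between 15000 nM and 100000 nM. This estimate means an expected step of an at least 1.2-fold lower number from compound 2 to compound 3 (0.09 log units; that floor lies within the scatter), and a reading that is again only a limit is expected to be quite likely.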

Compound 3, half-maximal inhibitory concentration: > 50000 nM
Compound 3: only a limit was reported; the forecaster's own chance of this, stated with the estimate: 45%; at least 1.2-fold (0.09 log units) between middle value and limit.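

Compound 2 and compound 3 both read only as limits in this assay, so no step can be read between them: the limit of > 50000 nM in this assay, at which 2 of the 3 values shown sit.

Whether the double bond drawn Z in compound 2 and E in compound 3 shifts inhibition at all, and in which direction or by how much, stays open in the compounds shown.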